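The source may hold more compounds than are shown below. What is called first, only, known or untested is meant among the compounds shown, and "the series" means these compounds.

Measured compounds in an ADME assay on WI-38 cells (Homo sapiens) for cytotoxicity, read by MTT assay, with a stated time of 72 h; on this read-out higher numbers stand for weaker inhibition and lower numbers for stronger inhibition:
- compound 1, `O=C(CCc1cccc2c1B(O)OC2)Nc1cccc(-c2ccccc2)c1`: 12000 nM
- compound 2, `O=C(CCc1cccc2c1B(O)OC2)Nc1cccc(-c2cccc(Cl)c2)c1`: 58000 nM
- compound 3, `O=C(CCc1cccc2c1B(O)OC2)Nc1cccc(-c2ccc(Cl)cc2)c1`: 9800 nM

Compound 3 carries the lowest of the three numbers, though compound 1 stands within the scatter of it, a 1.2-fold lower number from compound 1 to compound 3 (0.09 log units; within the scatter), and only compound 2 is clearly apart, a 5.9-fold lower number from compound 2 to compound 3 (0.77 log units; beyond the scatter). Compound 4, `N#Cc1ccc(-c2cccc(NC(=O)CCc3cccc4c3B(O)OC4)c2)cc1`, differs from compound 3 by cyano in place of chloro on an aromatic carbon. Among the compounds with values here, no measured step introduces a cyano group anywhere. The nearest evidence is the exchange of hydrogen for chloro at this same place, a 1.2-fold lower number from compound 1 to compound 3 (0.09 log units; within the scatter), which stayed within the scatter, while chloro at the other place on that ring did move the number, a 4.8-fold higher number from compound 1 to compound 2 (0.68 log units; beyond the scatter). On compounds 1 and 3 the position para to a large group has so far carried a substituent without a shift in this assay; a further exchange there is expected to stay near the scatter, and the range is set wide since no direct comparison exists. For compound 4 the expected step is a 1.2-fold higher number from compound 3 to compound 4 (0.09 log units; within the scatter). Compound 4 is estimated at 12000 nM, between 4000 nM and 36000 nM.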

Compound 4, half-maximal inhibitory concentration: 12000 nM
Estimate against measurement, compound 4: no gap at the digits printed; measured number inside the range.
By their numbers in this assay, from the lowest: compounds 3, 1 and 4 (each within the scatter of the next); then compound 2.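

In this assay, the position para to a large group now carries a second kind of substituent with no shift beyond the scatter: cyano in place of chloro gives (a 1.2-fold higher number from compound 3 to compound 4 (0.09 log units; within the scatter)), and cyano in place of hydrogen gives (no change at the digits printed from compound 1 to compound 4 (within the scatter)). Hydrogen, chloro and cyano at this position thus stand within the scatter of one another, which the single exchange of hydrogen for chloro could not show. The 3-chlorophenyl compound stays apart from the new compound as well (a 4.8-fold lower number from compound 2 to compound 4 (0.68 log units; beyond the scatter)).

No measurement at hand accounts for this flat response. Still open, as far as these compounds go, is whether an amine, a carboxylic acid or a longer chain at this position would stay as close, and whether cyano at the other place on that ring would move the number as chloro did.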